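Methoxy for methyl on the urea aryl of compound 3

The compounds below may be only part of what the source reports. "The series", "measured", "known", "first", "only" and "open" are said of these compounds alone.

Of the compounds shown here, three sharing one core have been measured in an assay on isolated protein for inhibition of serine/threonine-protein kinase PAK 1 (Homo sapiens), read by ADP-Glo, with a stated time of 40 min; a lower number here means a stronger inhibitor, a higher number a weaker inhibitor. Compound 1 `O=C(NC1CCN(c2ncnc3[nH]ncc23)CC1)c1ccc(F)cc1` gives 4540 nM, compound 2 `O=C(NC1CCN(c2ncnc3[nH]ncc23)CC1)c1ccc(Br)cc1` gives 16400 nM, and compound 3 `Cc1ccc(NC(=O)NC2CCN(c3ncnc4[nH]ncc34)CC2)cc1` gives 4710 nM. Compound 3 thus holds the second highest of the three numbers: its gap to compound 1 is within the scatter, while a 3.5-fold lower number from compound 2 to compound 3 (0.54 log units; beyond the scatter) is a modest step beyond it. Among the measured compounds shown here, the only other step, a 3.6-fold higher number from compound 1 to compound 2 (0.56 log units; beyond the scatter), also changes a substituent on the terminal ring.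

Compound 4 `COc1ccc(NC(=O)NC2CCN(c3ncnc4[nH]ncc34)CC2)cc1` differs from compound 3 in one place: methoxy in place of methyl on an aromatic carbon. For the measured compounds named here, no measured step exchanges methyl for methoxy, so the bearing of the recorded steps is indirect; they show that swaps of the group para to a large group on this ring have moved this assay by at most a modest amount, and that is the size expected here, with no direction called. Compound 4 is therefore estimated at 4500 nM, between 1800 nM and 11000 nM, a change of a 1.0-fold lower number from compound 3 to compound 4 (0.02 log units; within the scatter) that is expected to stay within the scatter.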

Compound 4, half-maximal inhibitory concentration: 6370 nM
Beside the measured number, compound 4's estimate is 1.4-fold (0.15 log units) below it; the measured number falls inside the stated range.
By their numbers in this assay, from the lowest: compounds 1, 3 and 4 (each within the scatter of the next); then compound 2.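

In this assay the direct exchange on this ring, a 1.4-fold higher number from compound 3 to compound 4 (0.13 log units; within the scatter) shows that methoxy, with one more heavy atom and one hydrogen-bond acceptor, can take the place of methyl para to a large group with no change that stands clear of the scatter. Among the compounds shown here, the earlier compounds showed only that swaps on this ring could move the number, and this is the first swap at this place within the urea series. Against the fluoro and bromo amides the picture holds, with a 1.4-fold higher number from compound 1 to compound 4 (0.15 log units; within the scatter) and a 2.6-fold lower number from compound 2 to compound 4 (0.41 log units; beyond the scatter) although each of these steps replaces the whole group on the carbonyl carbon, not the methoxy alone.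

On these data alone, whether ethoxy, chloro or an amine at this place would move the number stays open. Nothing at hand speaks to the reason for these numbers.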